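The source may hold more compounds than are shown below. What is called first, only, known or untested is meant among the compounds shown, and "the series" means these compounds.

In a functional assay on MCF7 cells (Homo sapiens) for cytotoxicity, read by sulforhodamine B assay (a lower number here means a stronger inhibitor of growth, a higher number a weaker inhibitor of growth), compound 1 `CC1=CC[C@@H]([C@@](C)(O)CCCC(C)(C)NC=S)CC1` gives 63100 nM as its concentration for total growth inhibition. Compound 2 `COc1ccc(/C=N\NC(=S)NC(C)(C)CCC[C@](C)(O)[C@@H]2CC=C(C)CC2)cc1`, which carries a 4-methoxyphenyl group on a carbon with a double bond to nitrogen, gives 94900 nM on the same read-out. These two values lie within the usual scatter of each other, so compound 2 stands level with compound 1 on the numbers available. Compound 3 `CC1=CC[C@@H]([C@@](C)(O)CCCC(C)(C)NC(=S)N/N=C\c2cccc([N+](=O)[O-])c2)CC1` has not yet been measured. It has 3-nitrophenyl in place of 4-methoxyphenyl on a carbon with a double bond to nitrogen and is otherwise the same as compound 2. Among the compounds with values here, no measured pair differing in one place is available to size such an exchange, and the data give no direction for it. In this assay no step beyond the scatter is expected, and that expectation takes compound 2 at 94900 nM as its starting point. The estimated 1.3-fold lower number from compound 2 to compound 3 (0.10 log units; within the scatter) stays inside the scatter. For compound 3 the estimated value is 75000 nM with an expected range of 30000 nM to 150000 nM across repeat measurements.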

Compound 3, concentration for total growth inhibition: 18300 nM
Estimate against measurement, compound 3: 4.1-fold (0.61 log units) above, and the stated range ends above it.
By their numbers in this assay, from the lowest: compound 3; then compounds 1 and 2 (each within the scatter of the next).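

In this assay, the group on a carbon with a double bond to nitrogen proves able to shift the read-out: 3-nitrophenyl in place of 4-methoxyphenyl gives a 5.2-fold lower number from compound 2 to compound 3 (0.71 log units; beyond the scatter), a modest step that lies beyond the scatter. Within the data shown here, the earlier compounds offered no measured pair differing in one place, so this is the first exchange whose size can be read, and it shows that this position is not silent. No measurement at hand bears on why the step occurs.

This single pair changes both the substituent and where it stands on the phenyl ring, so the compounds shown cannot say whether the step follows the nitro group, the loss of methoxy or the change in placement; 4-nitrophenyl and 3-methoxyphenyl would separate these readings. As far as these compounds go, whether plain phenyl or a ring carrying an amine or a carboxylic acid would fall in line with compound 2 or with compound 3 also stays open, as does whether the step would hold on any other core.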